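The source may hold more compounds than are shown below. What is called first, only, known or untested is meant among the compounds shown, and "the series" means these compounds.

Within the data shown here, compound 1 `C#CCOc1ccc2c(=O)c(-c3cc(OC)c(OC)cc3OC)coc2c1` is the only compound of the pair with a number in a functional assay on HCT-116 cells (Homo sapiens) for antiproliferative activity, read by MTT assay, with a stated time of 24 h; a lower number here means a stronger inhibitor, a higher number a weaker inhibitor: compound 1 gives 8050 nM. Compound 2 `COc1cccc(C(=O)Oc2ccc3c(=O)c(-c4cc(OC)c(OC)cc4OC)coc3c2)c1` sits at the limit of > 10000 nM in this assay, at which 1 of the 2 values shown sits; in this assay compound 2 gives > 10000 nM, a limit of the assay and not a number. The measured step is an at least 1.2-fold higher number from compound 1 to compound 2 (0.09 log units; that floor lies within the scatter). Compound 3 `COc1cc(OC)c(-c2coc3cc(OCC(=O)c4cccc(C(F)(F)F)c4)ccc3c2=O)cc1OC` differs from compound 1 by (3-(trifluoromethyl)phenyl)carbonyl in place of ethynyl on a saturated chain carbon bound to an oxygen on an aromatic ring. That change sits on the chain carbon rather than on the oxygen, so the measured step only loosely bears on it; a step toward a higher number is expected, a 1.5-fold higher number from compound 1 to compound 3 (0.17 log units; within the scatter). Compound 3 is therefore estimated at 12000 nM, expected between 4000 nM and 40000 nM.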

Compound 3, half-maximal inhibitory concentration: > 10000 nM
Compound 3: no number, only a limit; the forecaster's own chance of this, stated with the estimate: 55%; the middle value is on the limit's open side.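

In this assay compound 3 gives only a limit of the assay, not a number, and its step is a floor: an at least 1.2-fold higher number from compound 1 to compound 3 (0.09 log units; that floor lies within the scatter). A (3-(trifluoromethyl)phenyl)carbonyl on the saturated chain carbon thus ends at the same limit as the (3-methoxyphenyl)carbonyl on the oxygen, and the two placements cannot be told apart: the limit of > 10000 nM in this assay, at which 2 of the 3 values shown sit.

From the compounds shown here alone, how far compound 2 and compound 3 lie past that limit stays unknown, so neither can be ranked against compound 1. Going by these compounds, whether an amine, a carboxylic acid or a longer alkyl chain at this place gives a readable number stays open.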